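The source may report more compounds than this note shows. Statements on the series, on what has been measured and on what is new or still open speak of the compounds shown alone.

Measured so far:
Compound 1, `CCc1cc(C)c(C(=O)N=C(N)N)cc1S(C)(=O)=O`: 4.8 nM
Compound 2, `CCSc1cc(C)c(C(=O)N=C(N)N)cc1S(C)(=O)=O`: 5.9 nM
Compound 3, `Cc1cc(SC(C)(C)C)c(S(C)(=O)=O)cc1C(=O)N=C(N)N`: 22 nM

In a functional assay for inhibition of sodium/hydrogen exchanger (Oryctolagus cuniculus) (on this read-out higher numbers stand for weaker inhibition and lower numbers for stronger inhibition), compound 3 gives the highest of the three numbers; compound 2 sits nearest with its value, compound 1 furthest. The two steps leading to compound 3 are both beyond the scatter: a 4.6-fold higher number from compound 1 to compound 3 (0.66 log units; beyond the scatter) and a 3.7-fold higher number from compound 2 to compound 3 (0.57 log units; beyond the scatter), whereas a 1.2-fold higher number from compound 1 to compound 2 (0.09 log units; within the scatter) stays within it.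

Compound 4, `CCOc1cc(C)c(C(=O)N=C(N)N)cc1S(C)(=O)=O`, is unmeasured. Against compound 3 the change is ethoxy in place of (tert-butyl)sulfanyl on an aromatic carbon.

The step that bears most directly on this is a 3.7-fold higher number from compound 2 to compound 3 (0.57 log units; beyond the scatter), a modest rise on going to the larger group on the sulfur; compound 4 returns to an ethyl-sized substituent, here as ethoxy, and compound 2 and compound 1 show that ethylsulfanyl and ethyl give numbers within the scatter of each other. The expectation is therefore a lower number in this assay for compound 4, by a modest step, a 3.7-fold lower number from compound 3 to compound 4 (0.56 log units; beyond the scatter), bringing it back toward compound 1 and compound 2. Compound 4 is estimated at 6 nM with a range of 2.5 nM to 15 nM.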

Compound 4, half-maximal inhibitory concentration: 19 nM
Compound 4: the middle estimate sits 3.2-fold (0.50 log units) below what was measured; the whole stated range lies below it.
By their numbers in this assay, from the lowest: compounds 1 and 2 (each within the scatter of the next); then compounds 4 and 3 (each within the scatter of the next).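

In this assay, ethoxy on this aromatic carbon, ortho to a methylsulfonyl group, does not match ethyl or ethylsulfanyl, with a 4.0-fold higher number from compound 1 to compound 4 (0.60 log units; beyond the scatter) and a 3.2-fold higher number from compound 2 to compound 4 (0.51 log units; beyond the scatter) as the two steps, so putting oxygen in place of the sulfur of ethylsulfanyl is not a neutral change here. Replacing (tert-butyl)sulfanyl with ethoxy gives a 1.2-fold lower number from compound 3 to compound 4 (0.06 log units; within the scatter) and so, at this position, fewer heavy atoms in the group do not by themselves lower the number. Across these four compounds the number does not follow group size alone, since compound 3 and compound 4 fall together, apart from compound 1 and compound 2.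

No measurement at hand accounts for the ethoxy result. From the compounds shown here alone, whether methoxy, propoxy or an amine here would sit with ethoxy or with ethyl remains open.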